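The source may report more compounds than this note shows. Statements on the series, on what has been measured and on what is new or still open speak of the compounds shown alone.

Compound 1 `COc1ccc(N/C=C\C(=O)c2nc(-c3ccc(OC)cc3)n3ccccc23)cc1` is one of two measured members of the series. In a functional assay on MDA-MB-231 cells (Homo sapiens) for cytotoxicity, read by MTT assay, with a stated time of 48 h (a lower number here means a stronger inhibitor, a higher number a weaker inhibitor), compound 1 gives > 30000 nM, which is a limit of the assay rather than a number. Compound 2 `COc1ccc(-c2nc(C(=O)/C=C\Nc3ccc(F)cc3)c3ccccn23)cc1` carries fluoro in place of methoxy on an aromatic carbon; in this assay compound 2 gives > 30000 nM, again a limit. The step that the two limits leave unreadable from compound 1 to compound 2 cannot be read in size or direction. Among the measured compounds shown here, the only evidence on the measured steps is the limit of > 30000 nM in this assay, at which 2 of the 2 values shown sit.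

Compound 3 `COc1ccc(N/C=C\C(=O)c2nc(-c3ccc(C(F)(F)F)cc3)n3ccccc23)cc1` differs from compound 1 by trifluoromethyl in place of methoxy on an aromatic carbon. For the measured compounds named here, no measured step bears on this change with a readable size: the one step available, from compound 1 to compound 2, has both ends at the limit, and no direction beyond the scatter can be set from it. For compound 3 the expected step is a number no higher from compound 1 to compound 3 (the limit leaves the size open), kept near zero with wide uncertainty. Compound 3 is estimated in this assay at 30000 nM, with a range from 8000 nM to 100000 nM, and a limit rather than a number is judged the more likely outcome.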

Compound 3, half-maximal inhibitory concentration: > 30000 nM
Compound 3: a limit, no number (the forecaster's own chance of this, stated with the estimate: 70%); the middle value sits exactly at the limit.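

In this assay compound 3 gives > 30000 nM, which is a limit of the assay and not a number. Compound 1 also stands at a limit, so the step between compound 1 and compound 3 cannot be read in size or direction. The compounds shown leave open which change to the shared core, if any, would give a readable value: the limit of > 30000 nM in this assay, at which 3 of the 3 values shown sit.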